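Same atoms, rearranged: can compound 3 recover?

A few compounds are considered here, and "the series" means these few. Any claim that something is new, unique, unknown or untested is made for them only; others in the source may bear on it.

In a functional assay on MV4-11 cells (Homo sapiens) for antiproliferative activity, read by resazurin assay, with a stated time of 72 h (on this read-out higher numbers stand for weaker inhibition of growth and lower numbers for stronger inhibition of growth), compound 3 (`CC(=O)N1CCCN(c2cccc(Nc3nccc(-c4c[nH]c5cccnc45)n3)c2)CC1`) gives 688 nM, the highest number and so the weakest inhibition of the measured set. Compound 1 (`CC(=O)N1CCCN(c2cccc(Nc3nccc(-c4c[nH]c5ncccc45)n3)c2)CC1`) gives 20 nM, and compound 2 (`CC(=O)N1CCCN(c2cccc(Nc3nccc(-c4cnc5n(C)cccc4-5)n3)c2)CC1`) gives 24 nM. Compound 4 (`CC(=O)N1CCCN(c2cccc(Nc3nccc(-c4n[nH]c5ccccc45)n3)c2)CC1`) has the same atoms as compound 3, joined differently: a group of 9 heavy atoms (7 carbon, 2 nitrogen; one five-membered aromatic ring with 2 hetero atoms, one six-membered aromatic ring of carbon only) in place of a group of 9 heavy atoms (7 carbon, 2 nitrogen; one five-membered aromatic ring with 1 hetero atom, one six-membered aromatic ring with 1 hetero atom), on an aromatic carbon. The group that enters is 1H-indazol-3-yl. Rearranging this group's atoms mattered before, with a 34-fold higher number from compound 1 to compound 3 (1.54 log units; beyond the scatter), while adding one carbon did not, with a 1.2-fold higher number from compound 1 to compound 2 (0.08 log units; within the scatter). Within the data shown here, no measured compound has this new group, so the guidance is loose. A partial recovery is expected, with a 4.6-fold lower number from compound 3 to compound 4 (0.66 log units; beyond the scatter) as the estimated step. The estimate for compound 4 is 150 nM, with an expected range of 40 nM to 600 nM.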

Compound 4, concentration for 50% growth inhibition: 18 nM
For compound 4 the middle estimate is 8.3-fold (0.92 log units) above the measured one, outside the stated range (below it).
By their numbers in this assay, from the lowest: compounds 4, 1 and 2 (each within the scatter of the next); then compound 3.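

With the same atoms at this place on the shared core, 1H-indazol-3-yl gives a 38-fold lower number from compound 3 to compound 4 (1.58 log units; beyond the scatter), so the large loss in compound 3 comes with that one arrangement, not with every rearrangement of these atoms. Compound 4 also stands level with the two better compounds, with a 1.1-fold lower number from compound 1 to compound 4 (0.05 log units; within the scatter) and a 1.3-fold lower number from compound 2 to compound 4 (0.12 log units; within the scatter), so a six-membered ring of carbon only serves here as well as one holding a nitrogen. Nothing available explains why the arrangements differ. As far as these compounds go, whether a fluorine or an amine on the six-membered ring of 1H-indazol-3-yl would keep the number this low remains open.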